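Swapping butyl for methoxymethyl on the amide nitrogen

The compounds below may be only part of what the source reports. "The series", "measured", "known", "first", "only" and "open" are said of these compounds alone.

In a functional assay for agonist activity at follicle-stimulating hormone receptor (Homo sapiens), read by a luciferase reporter (on this read-out higher numbers stand for an effect only at larger amounts of compound and lower numbers for an effect already at smaller amounts), compound 1 `CCCCCCN1CC(=O)N(C)[C@H](Cc2ccc(-c3cc(OC)c(OC)c(OC)c3)cc2)C1=O` gives only a limit of the assay, > 50000 nM. Compound 2 `CCCCCCN1C(=O)[C@H](Cc2ccc(-c3cccc(CN(CCCC)C(C)=O)c3)cc2)N(C)C(=O)[C@@H]1C` gives 150 nM, and compound 3 `CCCCCCCCN1C(=O)[C@H](Cc2ccc(-c3cccc(CN(CCCC)C(C)=O)c3)cc2)N(C)C(=O)[C@@H]1C` gives 14 nM, the lowest of the two numbers recorded. Among the compounds with values here, the step of an 11-fold lower number from compound 2 to compound 3 (1.03 log units; beyond the scatter) is the only measured step, and it concerns the chain on the ring nitrogen. Compound 4 `CCCCCCCCN1C(=O)[C@H](Cc2ccc(-c3cccc(CN(COC)C(C)=O)c3)cc2)N(C)C(=O)[C@@H]1C` differs from compound 3 by methoxy in place of propyl on a saturated chain carbon bound to an amide-type nitrogen. Within the data shown here, no measured step touches this part of the molecule, so the large step between compound 2 and compound 3 gives no guidance here, and no step beyond the scatter is anticipated. Compound 4 is therefore expected at about 25 nM, with a range from 7 nM to 100 nM. The step of a 1.8-fold higher number from compound 3 to compound 4 (0.25 log units; within the scatter) is thus estimated to be small.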

Compound 4, half-maximal effective concentration: 9.7 nM
Compound 4: the middle estimate sits 2.6-fold (0.41 log units) above what was measured, within the range that was stated.
By their numbers in this assay, from the lowest: compounds 4 and 3 (each within the scatter of the next); then compound 2. At a limit, above all of these: compound 1.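

Swapping butyl for methoxymethyl on the amide-type nitrogen gives, in this assay, a 1.4-fold lower number from compound 3 to compound 4 (0.16 log units; within the scatter), so the two compounds cannot be told apart. Within the data shown here, this shows what the earlier compounds did not: this position, left unchanged in them, can carry a chain with an oxygen in it and keep the number of compound 3. Nothing at hand accounts for this result.

From the compounds shown here alone, whether the same position would also take an amine, a carboxylic acid or a longer chain remains open. So does whether the swap would hold with the shorter ring-nitrogen chain of compound 2.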